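Chloro on the phenyl of compound 3

A few compounds are considered here, and "the series" means these few. Any claim that something is new, unique, unknown or untested is made for them only; others in the source may bear on it.

- compound 1 `COc1ccccc1/C=C/C(=O)c1c(O)cc2occc2c1OC`: 30000 nM
- compound 2 `COc1c(C(=O)/C=C/c2ccc(Cl)cc2)c(O)c(Br)c2occc12`: 5090 nM
- compound 3 `C=CCc1c(O)c(C(=O)/C=C/c2ccccc2)c(OC)c2ccoc12`: 3790 nM

All three values come from a functional assay on ACHN cells (Homo sapiens) for inhibition, with a stated time of 48 h; a lower number here means a stronger inhibitor of growth, a higher number a weaker inhibitor of growth. Compound 3 at 3790 nM lies within the scatter of compound 2, while compound 1 at 30000 nM lies beyond the scatter from compound 3.

Compound 4 `C=CCc1c(O)c(C(=O)/C=C/c2ccc(Cl)cc2)c(OC)c2ccoc12` has chloro in place of hydrogen on an aromatic carbon, para to a large group, taking phenyl to 4-chlorophenyl (chloro in place of hydrogen on an aromatic carbon). For the measured compounds named here, no measured pair isolates this change. Compound 2 also carries 4-chlorophenyl, differs elsewhere, and gives 5090 nM, so only a small step is expected, with no change beyond the scatter. The expected size is a 1.3-fold lower number from compound 3 to compound 4 (0.10 log units; within the scatter). For compound 4 the estimate is 3000 nM, with an expected range of 1200 nM to 7500 nM.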

Compound 4, concentration for 50% growth inhibition: 2310 nM
The estimate for compound 4 lay 1.3-fold (0.11 log units) above the measured number; low and high end bracket the measured number.
By their numbers in this assay, from the lowest: compounds 4, 3 and 2 (each within the scatter of the next, the first and the last beyond it); then compound 1.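

In this assay, for the compounds shown here, chloro in place of hydrogen on an aromatic carbon, para to a large group, gives a 1.6-fold lower number from compound 3 to compound 4 (0.22 log units; within the scatter) and so provides the first direct reading at this position, with no change beyond the scatter. Going by these compounds alone, with 4-chlorophenyl held constant, allyl in place of bromo on an aromatic carbon gives a 2.2-fold lower number from compound 2 to compound 4 (0.34 log units; beyond the scatter) and is the only modest step here. No available evidence bears on the origin of either step.

As far as these compounds go, whether a nitrile or an amine at the chloro position would fit the same small step remains open. So does the effect of a longer chain in place of allyl.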